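The compounds below may be only part of what the source reports. "The series", "measured", "known", "first", "only" and "open" are said of these compounds alone.

Measured so far in a functional assay on UACC-62 cells (Homo sapiens) for cytotoxicity, read by sulforhodamine B assay, with a stated time of 48 h, tested at 0.001 uM; on this read-out lower numbers stand for a stronger effect and higher numbers for a weaker effect at the one concentration tested:
compound 1 `COc1cc(C)cc(-c2c(-c3ccnc(-c4ccc(C(C)=O)cc4)c3)cnn2CC#N)c1` gives 93%
compound 2 `COc1cc(C)cc(-c2nn(CC#N)cc2-c2ccc(-c3cccc(C(C)=O)c3)nc2)c1` gives 94%
compound 3 `Cc1cc(O)cc(-c2nn(CC#N)cc2-c2ccnc(-c3ccc(N(C)C)cc3)c2)c1` gives 90%

At this low test concentration all three numbers fall in a narrow band and each marks only a weak effect. Compound 1 stands second highest of the three; the nearest number is that of compound 2, a little higher and within the scatter, and the furthest is that of compound 3, a little lower and also within the scatter. Going by the values given here, no pair of these three can be told apart with confidence.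

Compound 4 `COc1cc(C)cc(-c2c(-c3ccnc(-c4ccc(N(C)C)cc4)c3)cnn2CC#N)c1` differs from compound 1 in one place: dimethylamino in place of acetyl on an aromatic carbon. The group that enters is the same one that compound 3 carries, but compound 3 differs from compound 1 in more than this one place, so its number only shows that a member carrying dimethylamino sits in the same band as the others. Among the compounds with values here, no single-change step between measured compounds exists for this series, so nothing in the data points to a move beyond the scatter.

The step from compound 1 to compound 4 in this assay is therefore expected to be small, if anything toward a slightly lower number: a number 2 percentage points lower from compound 1 to compound 4 (within the scatter). For compound 4 the estimate is 91%, with a range from 84% to 98%.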

Compound 4, a percentage reported as activity, at one concentration (the size of the read-out at that concentration, not a potency): 96%
Beside the measured number, compound 4's estimate is 5 percentage points below it, within the range that was stated.
By their numbers in this assay, from the lowest: compounds 3, 1, 2 and 4 (each within the scatter of the next).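

Within this assay, the exchange of 4-acetylphenyl for 4-(dimethylamino)phenyl gives a number 3 percentage points higher from compound 1 to compound 4 (within the scatter) and is the first single-change step available in this series. The earlier compounds shown here could only suggest that a dimethylamino-bearing member sat in the same band, whereas this pair tests the exchange directly on the shared core, at an aromatic carbon para to a large group, and does not separate the two groups at this concentration. Both groups are open-chain and uncharged, with the same counts of heavy atoms and hydrogen-bond acceptors, and no measurement at hand bears on this result.

From the compounds shown here alone, whether a carboxylic acid, a primary amine or a longer alkyl chain at this position would move the number in this assay beyond the scatter remains open. Also open, going by these compounds, is whether acetyl and dimethylamino stay indistinguishable at higher concentrations, where the read-out may leave this narrow band of weak effects and give the step more room to show.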